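This account rests on a few compounds, and the source may have more. Where it says the series, first, only, none or still open, it means among the compounds named here.

Measured compounds in a functional assay on SK-OV-3 cells (Homo sapiens) for cytotoxicity; on this read-out higher numbers stand for weaker inhibition and lower numbers for stronger inhibition:
- compound 1 `O=C(CCCCCCc1nc2ccccc2[nH]1)NO` gives 2700 nM
- compound 2 `O=C(CCCCCCc1nc2ccc(-c3ccc(F)cc3)cc2[nH]1)NO` gives 1200 nM
- compound 3 `O=C(CCCCCCc1nc2ccc(-c3ccccc3F)cc2[nH]1)NO` gives 7400 nM

Compound 3 carries the highest number of the three; its nearest neighbour is compound 1 and its most distant is compound 2, both steps lying beyond the scatter. Compound 4 `COc1ccc(-c2ccc3nc(CCCCCCC(=O)NO)[nH]c3c2)cc1` is not yet measured. It differs from compound 3 in one place: 4-methoxyphenyl in place of 2-fluorophenyl on an aromatic carbon.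

Going by the values given here, two measured steps bear on this change. Putting 2-fluorophenyl in place of 4-fluorophenyl gave a 6.2-fold higher number from compound 2 to compound 3 (0.79 log units; beyond the scatter), while the hydrogen-to-4-fluorophenyl step gave a 2.3-fold lower number from compound 1 to compound 2 (0.35 log units; beyond the scatter) and the hydrogen-to-2-fluorophenyl step gave a 2.7-fold higher number from compound 1 to compound 3 (0.44 log units; beyond the scatter). The group that enters in compound 4 is, like 4-fluorophenyl, substituted at the 4-position, and on that basis a lower number than compound 3 is expected, of a size comparable to reversing the step from compound 2. For compound 4 the expected step is a 4.9-fold lower number from compound 3 to compound 4 (0.69 log units; beyond the scatter). Compound 4 is therefore estimated at 1500 nM, with a range from 600 nM to 4000 nM.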

Compound 4, half-maximal inhibitory concentration: 3100 nM
The estimate for compound 4 lay 2.1-fold (0.32 log units) below the measured number; measured number inside the range.
By their numbers in this assay, from the lowest: compound 2; then compounds 1 and 4 (each within the scatter of the next); then compound 3.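

In this assay, methoxy in place of fluoro on the phenyl group gives a 2.6-fold higher number from compound 2 to compound 4 (0.41 log units; beyond the scatter), so the lower number seen with 4-fluorophenyl does not extend to every group substituted at the 4-position of that ring. The change from 2-fluorophenyl gives a 2.4-fold lower number from compound 3 to compound 4 (0.38 log units; beyond the scatter), yet 4-methoxyphenyl in place of hydrogen gives a 1.1-fold higher number from compound 1 to compound 4 (0.06 log units; within the scatter), which leaves this aryl group not separable from hydrogen at this position on the read-out. Nothing available accounts for these differences.

The compounds shown leave open how other groups on the phenyl ring, such as chloro, an amine or a carboxylic acid, would rank against fluoro and methoxy. Also open, going by these compounds, is whether 2-methoxyphenyl would follow 2-fluorophenyl to a higher number than hydrogen gives.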